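The source may hold more compounds than are shown below. What is called first, only, known or untested is meant among the compounds shown, and "the series" means these compounds.

Of the compounds shown here, three built on one shared core have been measured in a functional assay on PC-3 cells (Homo sapiens) for cytotoxicity, read by MTT assay, with a stated time of 48 h; a lower number here means a stronger inhibitor, a higher number a weaker inhibitor. Compound 1 `COc1cc(C(=O)C2Sc3nnc(-c4cc(OC)c(OC)c(OC)c4)n3NC2c2ccco2)cc(OC)c1OC` gives 52200 nM. Compound 2 `COc1cc(-c2nnc3n2NC(c2ccco2)C(C(=O)c2ccc(F)cc2)S3)cc(OC)c1OC` gives 27700 nM. Compound 3 `COc1cc(-c2nnc3n2NC(c2ccco2)C(C(=O)C2CC2)S3)cc(OC)c1OC` gives 95200 nM. Compound 3 thus carries the highest of the three numbers, though one of its steps, a 1.8-fold higher number from compound 1 to compound 3 (0.26 log units; within the scatter), stays within the scatter, while the other, a 3.4-fold higher number from compound 2 to compound 3 (0.54 log units; beyond the scatter), is the only move among these three that goes beyond it.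

The next step leads to compound 4 `COc1cc(-c2nnc3n2NC(c2ccco2)C(C(=O)c2cccc4ccccc24)S3)cc(OC)c1OC`, which differs from compound 3 in a single place: naphthalen-1-yl in place of cyclopropyl on a carbonyl carbon. Within the data shown here, two measured steps touch the same carbonyl carbon, each putting cyclopropyl in the place of an aromatic group. One was a 1.8-fold higher number from compound 1 to compound 3 (0.26 log units; within the scatter); the other was a 3.4-fold higher number from compound 2 to compound 3 (0.54 log units; beyond the scatter). Read in reverse, both say that an aromatic group on that carbon gave a number no higher, and in one case modestly lower, than cyclopropyl. Naphthalen-1-yl is again an aromatic group, so a modest lower number is expected for compound 4, a step of about a 2.4-fold lower number from compound 3 to compound 4 (0.38 log units; beyond the scatter). Among the measured compounds shown here, no measured compound carries naphthalen-1-yl, so this rests on two steps alone. Compound 4 is therefore estimated at 40000 nM, with a range from 15000 nM to 110000 nM.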

Compound 4, half-maximal inhibitory concentration: > 100000 nM
Compound 4 was reported as a limit; the forecaster's own chance of this, stated with the estimate: 5%; middle value at least 2.5-fold (0.39 log units) from the limit.
By their numbers in this assay, from the lowest: compounds 2, 1 and 3 (each within the scatter of the next, the first and the last beyond it). At a limit, above all of these: compound 4.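

In this assay, the result for compound 4 is a limit of the assay and not a number: the limit of > 100000 nM in this assay, at which 1 of the 4 values shown sits. Among these compounds, measured against 4-fluorophenyl, naphthalen-1-yl gives an at least 3.6-fold higher number from compound 2 to compound 4 (0.55 log units; beyond the scatter), so an aromatic group on this carbonyl carbon does not by itself keep the number low, something the earlier steps could not show, since there the aromatic groups stood level with cyclopropyl or modestly lower. The other two steps are less firm, with an at least 1.0-fold higher number from compound 3 to compound 4 (0.02 log units; that floor lies within the scatter) and an at least 1.9-fold higher number from compound 1 to compound 4 (0.28 log units; that floor lies within the scatter), and as both floors lie within the scatter, the larger naphthalen-1-yl group cannot yet be separated from cyclopropyl or from 3,4,5-trimethoxyphenyl at this place.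

Going by these compounds, how far the true number lies past the limit stays open, and with it whether naphthalen-1-yl truly differs from those two groups. Also open, on these data alone, is whether unsubstituted phenyl or naphthalen-2-yl on this carbonyl carbon would fall with the 4-fluorophenyl result or with the naphthalen-1-yl one, and what a dimethylamino group there would give.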